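The compounds below may be only part of what the source reports. "The series", "measured", "known", "first", "only" and "open" are said of these compounds alone.

In an assay on CHO cells for antagonist activity at transient receptor potential cation channel subfamily V member 1 (Homo sapiens), read by FLIPR and calcium flux (on this read-out higher numbers stand for weaker inhibition and lower numbers for stronger inhibition), compound 1 `CC(C(=O)NCc1ccc(C(F)(F)F)nc1Br)c1ccc(NS(C)(=O)=O)c(F)c1` gives 169 nM, the highest of the three numbers measured here, so it is the weakest inhibitor of the set. Compound 2 `CCC1CCC(c2nc(C(F)(F)F)ccc2CNC(=O)C(C)c2ccc(NS(C)(=O)=O)c(F)c2)CC1` gives 0.3 nM and compound 3 `CC(C(=O)NCc1ccc(C(F)(F)F)nc1C1CCC(C)(C)CC1)c1ccc(NS(C)(=O)=O)c(F)c1` gives 0.4 nM in this assay. The step from compound 1 to compound 4 `CC(C(=O)NCc1ccc(C(F)(F)F)nc1C1CCC(F)(F)CC1)c1ccc(NS(C)(=O)=O)c(F)c1` is 4,4-difluorocyclohexyl in place of bromo on an aromatic carbon, a change sitting next to the ring nitrogen of the shared core. Within the data shown here, two measured steps bear directly on it: replacing the bromo by a 4-ethylcyclohexyl gave a 560-fold lower number from compound 1 to compound 2 (2.75 log units; beyond the scatter), and replacing it by a 4,4-dimethylcyclohexyl gave a 420-fold lower number from compound 1 to compound 3 (2.63 log units; beyond the scatter). Both are large and point the same way, and the two cyclohexyl groups themselves differed only by a 1.3-fold higher number from compound 2 to compound 3 (0.12 log units; within the scatter), which is within the scatter. A 4,4-difluorocyclohexyl is a third six-membered ring in the same place, so a step of similar size and direction is expected in this assay, namely a 280-fold lower number from compound 1 to compound 4 (2.45 log units; beyond the scatter). Compound 4 is therefore estimated at 0.6 nM, most likely between 0.2 nM and 2.5 nM.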

Compound 4, inhibition constant: 1.5 nM
Estimate against measurement, compound 4: 2.5-fold (0.40 log units) below; measured number inside the range.
By their numbers in this assay, from the lowest: compounds 2 and 3 (each within the scatter of the next); then compound 4; then compound 1.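

In this assay, the 4,4-difluorocyclohexyl keeps most of the gain over bromo, with a 110-fold lower number from compound 1 to compound 4 (2.05 log units; beyond the scatter) and so a large drop, which makes it the third six-membered ring to give one at this place on the shared core. The two earlier rings could not be told apart, but this one can be separated from both, with a 3.8-fold higher number from compound 3 to compound 4 (0.57 log units; beyond the scatter) and a 5.0-fold higher number from compound 2 to compound 4 (0.70 log units; beyond the scatter) as modest steps beyond the scatter, so what the ring carries does change the result here, though far less than swapping bromo for a ring does. Nothing shown here explains why the difluoro ring gives the higher number.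

The compounds shown leave open how a plain cyclohexyl, with nothing added to the ring, would compare at this place. They also leave open what a ring containing an amine, such as piperidine, would do.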